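Thiophene Replaces the Naphthalene Group in Compound 4

The source may hold more compounds than are shown below. What is called first, only, known or untested is meant among the compounds shown, and "the series" means these compounds.

Three compounds share one core. Compound 1 `N#CC1=C(N)N(c2ccc(S(N)(=O)=O)cc2)C2=C(C(=O)CCC2)C1c1cccc([N+](=O)[O-])c1` carries 3-nitrophenyl on a saturated ring carbon, and in a functional assay on Ehrlich cells (Mus musculus) for antiproliferative activity, read by trypan blue exclusion, with a stated time of 2 h, tested at 25 ug/mL (on this read-out higher numbers stand for a stronger effect at the one concentration tested and lower numbers for a weaker effect), compound 1 gives 50%. Compound 2 `N#CC1=C(N)N(c2ccc(S(N)(=O)=O)cc2)C2=C(C(=O)CCC2)C1c1ccc(Cl)cc1Cl` carries 2,4-dichlorophenyl at that place, and in this assay compound 2 gives 50%; the step of no change at the digits printed from compound 1 to compound 2 (within the scatter). Compound 3 `COc1ccc(C2C(C#N)=C(N)N(c3ccc(S(N)(=O)=O)cc3)C3=C2C(=O)CCC3)c2ccccc12` carries 4-methoxynaphthalen-1-yl, and in this assay compound 3 gives 10%, the lowest of the three numbers, as the steps of a number 40 percentage points lower from compound 1 to compound 3 (beyond the scatter) and a number 40 percentage points lower from compound 2 to compound 3 (beyond the scatter) show.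

Compound 4 `N#CC1=C(N)N(c2ccc(S(N)(=O)=O)cc2)C2=C(C(=O)CCC2)C1c1cccs1` is not yet measured. It differs from compound 3 as follows: thiophen-2-yl in place of 4-methoxynaphthalen-1-yl on a saturated ring carbon. For the measured compounds named here, no measured compound carries thiophen-2-yl, so the change can be gauged only through the two steps that lead into compound 3, a number 40 percentage points lower from compound 1 to compound 3 (beyond the scatter) and a number 40 percentage points lower from compound 2 to compound 3 (beyond the scatter), both large. Read in reverse, removing 4-methoxynaphthalen-1-yl recovered the loss in each case, whichever other group stood there. Compound 4 is therefore expected to rise by a number 35 percentage points higher from compound 3 to compound 4 (beyond the scatter) in this assay, with wide uncertainty. The estimate for compound 4 is 45%, ranging from 20% to 70%.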

Compound 4, a percentage reported as activity, at one concentration (the size of the read-out at that concentration, not a potency): 80%
Beside the measured number, compound 4's estimate is 35 percentage points below it; the whole stated range lies below it.
By their numbers in this assay, from the lowest: compound 3; then compounds 1 and 2 (each within the scatter of the next); then compound 4.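

The place on the saturated ring carbon can carry more than the level shared by the two substituted phenyl groups: in this assay thiophen-2-yl gives a number 30 percentage points higher from compound 1 to compound 4 (beyond the scatter) and a number 30 percentage points higher from compound 2 to compound 4 (beyond the scatter), so compound 1 and compound 2 did not mark a ceiling there. Exchanging 4-methoxynaphthalen-1-yl for thiophen-2-yl also produces the widest step in the set, a number 70 percentage points higher from compound 3 to compound 4 (beyond the scatter), which shows how far this one place alone can move the read-out on the shared core. Nothing at hand gives a cause for these steps.

The compounds shown leave open whether the gain follows the sulfur atom or the five-membered ring, since thiophen-2-yl is the only such group among them. Furan-2-yl or thiophen-3-yl at this place would separate those two readings.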